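This account rests on a few compounds, and the source may have more. Where it says the series, first, only, none or still open, it means among the compounds named here.

Three members of the selenocyanate series have been measured: compound 1 `CCCCCCOC(=O)Nc1ccc([Se]C#N)cc1`, compound 2 `N#C[Se]c1ccc(NC(=O)Oc2ccc(F)cc2)cc1` and compound 3 `Cc1ccc(OC(=O)Nc2ccc([Se]C#N)cc2)cc1`. In a functional assay on CCRF-CEM cells (Homo sapiens) for cytotoxicity, read by MTT assay, with a stated time of 72 h (a lower number here means a stronger inhibitor of growth, a higher number a weaker inhibitor of growth), compound 1 gives 19700 nM, compound 2 gives 12600 nM and compound 3 gives 17400 nM. Among the compounds with values here, the single step available within this set, a 1.4-fold higher number from compound 2 to compound 3 (0.14 log units; within the scatter), lies within the scatter. Compound 3 holds the second highest of the three numbers, with compound 1 and compound 2 both within the scatter of it. Compound 4 `N#C[Se]c1ccc(NC(=O)Oc2ccccc2)cc1` differs from compound 3 by hydrogen in place of methyl on an aromatic carbon. Within the data shown here, no measured step removes a substituent from that ring altogether; the nearest comparison, the fluoro-to-methyl exchange, stayed within the scatter, so no movement beyond the scatter is expected here either. Compound 4 is estimated at 16000 nM, with a range of 8000 nM to 32000 nM. The step expected is a 1.1-fold lower number from compound 3 to compound 4 (0.04 log units; within the scatter), within the scatter.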

Compound 4, concentration for 50% growth inhibition: 22900 nM
For compound 4 the middle estimate is 1.4-fold (0.16 log units) below the measured one; the measured number falls inside the stated range.
By their numbers in this assay, from the lowest: compounds 2, 3, 1 and 4 (each within the scatter of the next).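

In this assay, hydrogen in place of methyl on the aromatic carbon para to a large group gives a 1.3-fold higher number from compound 3 to compound 4 (0.12 log units; within the scatter), and hydrogen in place of fluoro there gives a 1.8-fold higher number from compound 2 to compound 4 (0.26 log units; within the scatter), so the unsubstituted ring stays within the scatter of both substituted ones. Phenyl in place of hexyl on the oxygen gives a 1.2-fold higher number from compound 1 to compound 4 (0.07 log units; within the scatter), also within the scatter. No supporting evidence bears on these steps. Open, as far as these compounds go, is whether an amine or a carboxylic acid on that ring, or a longer chain on the oxygen, would move the number beyond the scatter.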